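From Compound 2 to Compound 3: Opening the Amide

A few compounds are considered here, and "the series" means these few. Any claim that something is new, unique, unknown or untested is made for them only; others in the source may bear on it.

The two measured compounds are compared in a functional assay on BXPC-3 cells (Homo sapiens) for inhibition, read by MTT assay, with a stated time of 7 days; on this read-out higher numbers stand for weaker inhibition and lower numbers for stronger inhibition. Compound 1 `O=C([C@@H]1CCCN(S(=O)(=O)c2ccc(S(=O)(=O)N3CC[C@@H](O)C3)cc2)C1)N1CCC(F)(F)CC1` gives 330 nM in this assay. Compound 2 `CCN(CC)S(=O)(=O)c1ccc(S(=O)(=O)N2CCC[C@@H](C(=O)N3CCOCC3)C2)cc1` gives 790 nM, the higher of the two numbers, with compound 1 standing clearly lower. Compound 3 `CCN(CC)S(=O)(=O)c1ccc(S(=O)(=O)N2CCC[C@@H](C(=O)N[C@@H]3CCOC3)C2)cc1` has not yet been measured; it differs from compound 2 by (oxolan-3-yl)amino in place of morpholin-4-yl on a carbonyl carbon. Among the measured compounds shown here, nothing among the measured compounds speaks to a change of this kind, so the expected step is a 1.1-fold higher number from compound 2 to compound 3 (0.06 log units; within the scatter), with no clear direction and no size beyond the scatter. Compound 3 is therefore estimated at 900 nM, with a range from 300 nM to 2700 nM.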

Compound 3, half-maximal inhibitory concentration: 2270 nM
Beside the measured number, compound 3's estimate is 2.5-fold (0.40 log units) below it; the range from low to high includes it.
By their numbers in this assay, from the lowest: compound 1; then compound 2; then compound 3.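

In this assay, (oxolan-3-yl)amino in place of morpholin-4-yl on a carbonyl carbon gives a 2.9-fold higher number from compound 2 to compound 3 (0.46 log units; beyond the scatter), so this position responds to the group on the carbonyl even when the heavy-atom count stays the same. The change adds a hydrogen-bond donor and a defined stereocentre and also alters the ring, and this single step cannot separate those features. Nothing available explains the weaker inhibition. Open, as far as these compounds go, is whether the amide hydrogen or the ring matters more, a question that cyclopentylamino or pyrrolidin-1-yl on the same carbonyl carbon could address. From the compounds shown here alone, the role of the opposite oxolan-3-yl stereoisomer also remains open.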